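Ring swap on a racemic pair of stereoisomers

The source may report more compounds than this note shows. Statements on the series, on what has been measured and on what is new or still open speak of the compounds shown alone.

Compound 1 `C[C@H](C(=O)Nc1cc(C2CC2)[nH]n1)c1ccc(N2CCNC2=O)cc1` gives 1270 nM
Compound 2 `C[C@@H](C(=O)Nc1cc(C2CC2)[nH]n1)c1ccc(N2CCNC2=O)cc1` gives 13200 nM
Compound 3 `CC(C(=O)Nc1cc(C2CC2)[nH]n1)c1ccc(N2CCNC2=O)cc1` gives 2250 nM

All three were tested in a functional assay on A2780 cells (Homo sapiens) for inhibition (a lower number here means a stronger inhibitor, a higher number a weaker inhibitor), and differ only in how one stereocentre is drawn. Among the measured compounds shown here, the one large step, a 10-fold higher number from compound 1 to compound 2 (1.02 log units; beyond the scatter), goes with the fact that compounds 1 and 2 differ only in the configuration as drawn and shows how far this read-out can move. Compound 3, drawn without a configuration, stands close to compound 1, with a 1.8-fold higher number from compound 1 to compound 3 (0.25 log units; within the scatter), and well away from compound 2, with a 5.9-fold lower number from compound 2 to compound 3 (0.77 log units; beyond the scatter).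

Compound 4 `CC(C(=O)Nc1cc(C2CC2)[nH]n1)c1ccc(-n2cnnc2O)cc1` is also drawn without a configuration, so it compares directly with compound 3. The change is a group of 6 heavy atoms (2 carbon, 3 nitrogen, 1 oxygen; one five-membered aromatic ring with 3 hetero atoms) in place of a group of 6 heavy atoms (3 carbon, 2 nitrogen, 1 oxygen; one five-membered non-aromatic ring with 2 hetero atoms), on an aromatic carbon. For the measured compounds named here, no measured step touches this group, so none gives a size for the swap. Going by the values given here, the only anchor is compound 3 at 2250 nM, and no shift beyond the scatter can be expected with confidence. The expected step is a 1.2-fold higher number from compound 3 to compound 4 (0.09 log units; within the scatter) in this assay, with its direction uncertain. For compound 4 the estimated value is 2800 nM, within an expected range from 700 nM to 11000 nM, kept wide for that reason.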

Compound 4, half-maximal inhibitory concentration: 8390 nM
For compound 4 the middle estimate is 3.0-fold (0.48 log units) below the measured one; the range from low to high includes it.
By their numbers in this assay, from the lowest: compounds 1 and 3 (each within the scatter of the next); then compounds 4 and 2 (each within the scatter of the next).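

Among the compounds shown here, until now only the stereocentre had varied, so this is the first measured change at the group on an aromatic carbon, para to a large group. In this assay, putting a five-membered aromatic ring with 3 hetero atoms in place of 2-oxoimidazolidin-1-yl gives a 3.7-fold higher number from compound 3 to compound 4 (0.57 log units; beyond the scatter), so this position responds to the identity of the ring, even though both groups have 6 heavy atoms and no net charge. Nothing in the data shown gives a reason for this step.

From the compounds shown here alone, both compounds in this step are drawn without a configuration, so it remains open whether the swap would have the same size in each separate stereoisomer, where the stereocentre alone gives a 10-fold higher number from compound 1 to compound 2 (1.02 log units; beyond the scatter). Also open, going by these compounds, is how this position responds to quite different groups, such as a simple amine or a carboxylic acid.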